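From acetyl to 2-chlorobenzoyl on the shared core

A few compounds are considered here, and "the series" means these few. Any claim that something is new, unique, unknown or untested is made for them only; others in the source may bear on it.

Compound 2 `CC(=O)N1c2ccccc2CCC1C(=O)Nc1ccccc1C(F)(F)F` gives only a limit in a functional assay on NCI-H23 cells (Homo sapiens) for cytotoxicity, read by sulforhodamine B assay, with a stated time of 72 h; on this read-out lower numbers stand for stronger inhibition of growth and higher numbers for weaker inhibition of growth: in that assay compound 2 reads > 80000 nM, which is a limit of the assay, namely (the limit of > 80000 nM in this assay, at which 1 of the 2 values shown sits). Compound 1 `CCCCCCCCC(=O)N1c2ccccc2CCC1C(=O)Nc1ccccc1C(F)(F)F` gives 4220 nM in this assay. Compound 3 `O=C(Nc1ccccc1C(F)(F)F)C1CCc2ccccc2N1C(=O)c1ccccc1Cl` differs from compound 2 by 2-chlorophenyl in place of methyl on a carbonyl carbon. Because an at least 18-fold higher number from compound 1 to compound 2 (1.27 log units; beyond the scatter) was a large rise when the heptyl was cut away, the entering 2-chlorophenyl is expected to lower the number again, by about an at least 13-fold lower number from compound 2 to compound 3 (1.12 log units; beyond the scatter). Compound 3 is therefore estimated at 6000 nM, with a range from 1500 nM to 40000 nM.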

Compound 3, concentration for 50% growth inhibition: 2150 nM
The estimate for compound 3 lay 2.8-fold (0.45 log units) above the measured number, within the range that was stated.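

In this assay, within the data shown here, 2-chlorophenyl in place of methyl on this carbonyl carbon gives an at least 37-fold lower number from compound 2 to compound 3 (1.57 log units; beyond the scatter), so a long chain is not the only group here that moves the compound well clear of the acetyl compound. Compound 2 reads only as a limit of the assay: the limit of > 80000 nM in this assay, at which 1 of the 3 values shown sits. The octyl chain and the 2-chlorophenyl ring stand level, with a 2.0-fold lower number from compound 1 to compound 3 (0.29 log units; within the scatter). On these data alone, whether the chlorine itself matters remains open, as does whether a plain phenyl, a butyl chain or an amine on this carbonyl carbon would do the same.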